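Trimethoxyphenyl amide series: saturating the acryloyl chain

This account rests on a few compounds, and the source may have more. Where it says the series, first, only, none or still open, it means among the compounds named here.

Measured compounds:
- compound 1 `COc1ccc(CN(C(=O)C=C(C)C)c2cc(OC)c(OC)c(OC)c2)cc1O`: 280 nM
- compound 2 `C/C=C/C(=O)N(Cc1ccc(OC)c(OC)c1)c1cc(OC)c(OC)c(OC)c1`: 39100 nM
- compound 3 `COc1cc(NCc2ccc(Br)cc2)cc(OC)c1OC`: > 80000 nM

In a functional assay on KYSE-450 cells (Homo sapiens) for inhibition, read by MTT assay, with a stated time of 48 h (on this read-out lower numbers stand for stronger inhibition and higher numbers for weaker inhibition), compound 1 gives 280 nM, the lowest of the two numbers recorded. Compound 2 gives 39100 nM in this assay, far above compound 1 and well beyond the usual scatter. Compound 3 reaches only a limit of the assay, > 80000 nM, so no number stands for it (the limit of > 80000 nM in this assay, at which 1 of the 3 values shown sits). Among the measured compounds shown here, compound 2 and compound 3 each differ from compound 1 in more than one place, so no single step between measured compounds can be read.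

The next compound, compound 4 `COc1ccc(CN(C(=O)C(C)C)c2cc(OC)c(OC)c(OC)c2)cc1O`, is not yet measured. It differs from compound 1 in one place: isopropyl in place of 2-methylprop-1-en-1-yl on a carbonyl carbon. The amide, the shared core and the hydroxy-methoxybenzyl group are kept. For the measured compounds named here, no measured pair reports what this particular change does. The expectation is a step in this assay toward a higher number, beyond the scatter but modest; the estimated step is a 4.3-fold higher number from compound 1 to compound 4 (0.63 log units; beyond the scatter). Compound 4 is therefore expected to give about 1200 nM in this assay, within a range from 300 nM to 5000 nM.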

Compound 4, half-maximal inhibitory concentration: 390 nM
Beside the measured number, compound 4's estimate is 3.1-fold (0.49 log units) above it; the range from low to high includes it.
By their numbers in this assay, from the lowest: compounds 1 and 4 (each within the scatter of the next); then compound 2. At a limit, above all of these: compound 3.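

In this assay, among the compounds shown here, isopropyl in place of 2-methylprop-1-en-1-yl on a carbonyl carbon gives the first step that can be read at a single place (a 1.4-fold higher number from compound 1 to compound 4 (0.14 log units; within the scatter)). At this position, then, the double bond outside aromatic rings and the one carbon that leaves with it can go without a difference beyond the scatter, so compound 1 and compound 4 read alike. Nothing on hand speaks to why these two groups read alike.

Still open, going by these compounds, is whether a cyclopropyl group, a longer chain, an amine or a carboxylic acid on this carbonyl carbon would keep the number. Also open, on these data alone, is what single changes to the hydroxy-methoxybenzyl group do while the isopropyl carbonyl stays in place.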